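Chloro for trifluoromethyl at the clearance limit

This account rests on a few compounds, and the source may have more. Where it says the series, first, only, none or still open, it means among the compounds named here.

Measured in an in vitro ADME assay on microsomes from Gut (Homo sapiens) for metabolic stability, using NADPH; on this read-out lower numbers stand for slow clearance and higher numbers for fast clearance:
Compound 1 `CC(C)(CO)CNC(=O)c1cc2cc(C#N)ccc2n1Cc1cc(Cl)cc(Cl)c1`: < 6 mL.min-1.g-1, a limit
Compound 2 `COc1ccc(Br)cc1Cn1c(C(=O)NCC(C)(C)CO)cc2cc(C#N)ccc21`: < 6 mL.min-1.g-1, a limit
Compound 3 `Cc1ccc(C(F)(F)F)cc1Cn1c(C(=O)NCC(C)(C)CO)cc2cc(C#N)ccc21`: < 6 mL.min-1.g-1, a limit

Compound 3 has no numerical value in this assay, only the limit < 6 mL.min-1.g-1. The two other compounds stand in the same position, as the record shows: the limit of < 6 mL.min-1.g-1 in this assay, at which 3 of the 3 values shown sit. The three compounds therefore offer no readable spread of clearance.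

Compound 4 `Cc1ccc(Cl)cc1Cn1c(C(=O)NCC(C)(C)CO)cc2cc(C#N)ccc21` departs from compound 3 in one place: chloro in place of trifluoromethyl on an aromatic carbon. This puts chloro in place of trifluoromethyl on an aromatic carbon, meta to a large group and para to a methyl group. Within the data shown here, the only measured step is a step that the two limits leave unreadable from compound 1 to compound 2. It also exchanges groups on an aromatic ring, but it yields no size and no direction to carry over.

The expectation therefore rests on compound 3 and its limit < 6 mL.min-1.g-1, and no step beyond the usual scatter is expected in this assay. No direction can be assigned to the change. The expected outcome is a step that the limit leaves unreadable from compound 3 to compound 4. The assay will most likely report only a limit again. Compound 4 is estimated at 4 mL.min-1.g-1, with an expected range from 2 mL.min-1.g-1 to 8 mL.min-1.g-1.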

Compound 4, intrinsic clearance in microsomes: < 6 mL.min-1.g-1
Compound 4 ended at the assay's limit; the forecaster's own chance of this, stated with the estimate: 85%; the middle value is on the limit's open side.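

The steps to compound 4 from compound 1, compound 2 and compound 3 cannot be read, since in this assay all four compounds give only a limit: the limit of < 6 mL.min-1.g-1 in this assay, at which 4 of the 4 values shown sit.

How far clearance truly differs among these compounds, and whether chloro in place of trifluoromethyl changes it at all, stays open.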